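Swapping the aryl group on a shared core

The compounds below may be only part of what the source reports. "The series", "measured", "known", "first", "only" and "open" are said of these compounds alone.

For the measured compounds named here, compound 2 `Brc1ccc(-c2cn3ccnc3c(-c3ccc4ncn(C5CCCCC5)c4c3)n2)cc1` has the higher of the two numbers measured so far in a functional assay on SF-268 cells (Homo sapiens) for inhibition, read by sulforhodamine B assay, with a stated time of 48 h, tested at 10 uM (a higher number here means more inhibition at the concentration tested (going by the name of the read-out), a lower number less inhibition), where compound 2 gives 15.5%. Compound 1 `CC(=O)c1ccc(-c2cn3ccnc3c(-c3ccc4ncn(C5CCCCC5)c4c3)n2)cc1` differs from it only by acetyl in place of bromo on an aromatic carbon, and in this assay compound 1 gives 5.01%. Going by the values given here, the single measured step, a number 10.5 percentage points higher from compound 1 to compound 2 (beyond the scatter), shows that exchanging the group on that outer ring can move the read-out modestly. Compound 3 `FC(F)(F)c1cccc(-c2cn3ccnc3c(-c3ccc4ncn(C5CCCCC5)c4c3)n2)c1` carries a further exchange at the same place: 3-(trifluoromethyl)phenyl in place of 4-bromophenyl on an aromatic carbon. Among the compounds with values here, no measured step covers a trifluoromethyl group, so the one step from compound 1 to compound 2 is only loosely related. With both measured numbers low, the read-out of compound 3 is expected to stay in the same region, with the step of a number 2.5 percentage points lower from compound 2 to compound 3 (within the scatter) expected to lie within the scatter. Compound 3 is therefore estimated at 13%, within a range of 0% to 30%.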

Compound 3, a percentage reported as inhibition, at one concentration (the size of the read-out at that concentration, not a potency): 3.3%
For compound 3 the middle estimate is 9.7 percentage points above the measured one; low and high end bracket the measured number.
By their numbers in this assay, from the lowest: compounds 3 and 1 (each within the scatter of the next); then compound 2.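

In this assay, a number 12.2 percentage points lower from compound 2 to compound 3 (beyond the scatter) shows that the level of compound 2 is not kept when 3-(trifluoromethyl)phenyl enters, while a number 1.7 percentage points lower from compound 1 to compound 3 (within the scatter) puts two quite different outer rings on a par. So far, then, 4-bromophenyl is the only group at this position that stands apart from the others, though all three numbers remain low. The change swaps both the group and where it sits on the outer ring, so this step cannot separate those two effects, and no measurement here explains the difference.

Still open, as far as these compounds go, is whether 3-bromophenyl or 4-(trifluoromethyl)phenyl would pull those two effects apart. Also open, from the compounds shown here alone, is how an outer ring carrying an amine or a carboxylic acid would read.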